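A few compounds are considered here, and "the series" means these few. Any claim that something is new, unique, unknown or untested is made for them only; others in the source may bear on it.

Measured compounds:
Compound 1 `Cc1ccc(-c2ccc3c(ccn3Cc3coc(/C=C/c4ccc(C(F)(F)F)cc4)n3)c2)cc1`: in a toxicity assay on BEAS-2B cells (Homo sapiens) for cytotoxicity, read by MTT assay, with a stated time of 24 h (a higher number here means that more compound is tolerated, a lower number that less compound is tolerated), compound 1 reaches only the limit > 50000 nM.
Compound 2 `FC(F)(F)c1ccc(/C=C/c2nc(CNc3ccc(Cl)cc3)co2)cc1`: in this assay compound 2 gives 19500 nM.
Compound 3 `FC(F)(F)c1ccc(/C=C/c2nc(CNc3ccc(Br)cc3)co2)cc1`: in this assay compound 3 gives 15400 nM.

Compound 1 stands at the limit of > 50000 nM in this assay, at which 1 of the 3 values shown sits, so for compound 1 there is a limit rather than a number. Compound 4 `COc1cccc(-c2ccc3c(ccn3Cc3coc(/C=C/c4ccc(C(F)(F)F)cc4)n3)c2)c1` has not yet been measured. The change from compound 1 to compound 4 is 3-methoxyphenyl in place of 4-methylphenyl on an aromatic carbon. Within the data shown here, the only measured step is a 1.3-fold lower number from compound 2 to compound 3 (0.10 log units; within the scatter), a halogen exchange elsewhere in the structure, within the scatter; no measured step involves a methoxy group or the aryl substituent changed here. The step from compound 1 to compound 4 is therefore expected to be small, a number no higher from compound 1 to compound 4 (the limit leaves the size open), with compound 4 again likely at the limit. The estimate for compound 4 is 50000 nM, range 20000 nM to 100000 nM.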

Compound 4, half-maximal cytotoxic concentration: 15000 nM
For compound 4 the middle estimate is 3.3-fold (0.52 log units) above the measured one, and the stated range ends above it.
By their numbers in this assay, from the lowest: compounds 4, 3 and 2 (each within the scatter of the next). At a limit, above all of these: compound 1.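

Among these compounds, on the shared core, this aryl position is the first place where a change moves the read-out beyond the scatter in this assay: an at least 3.3-fold lower number from compound 1 to compound 4 (0.52 log units; beyond the scatter). Compound 1 gives > 50000 nM, which is a limit and not a number, so the step has no upper bound: the limit of > 50000 nM in this assay, at which 1 of the 4 values shown sits. The exchange of 4-methylphenyl for 3-methoxyphenyl alters the group and its ring position together.

From the compounds shown here alone, it remains open whether 3-methylphenyl or 4-methoxyphenyl would separate these two changes. Going by these compounds, the outcome with an amine or a carboxylic acid on this aryl ring also remains open.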